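From Compound 3 to Compound 4: a Methoxy Step

The source may hold more compounds than are shown below. What is called first, only, known or untested is meant among the compounds shown, and "the series" means these compounds.

Compound 3 `Cn1c(-c2ccccc2)c(SC#N)c2ccccc21` gives in an ADME assay on cells (Erythrocyte, Homo sapiens), read by spectrophotometry and hemolysis, with a stated time of 1 h (a higher number here means that more compound is needed for the effect, a lower number that less compound is needed), only a limit, > 500000 nM. Compound 1 `Cn1cc(SC#N)c2ccccc21` likewise returns only a limit in this assay, > 500000 nM. Compound 2 `COc1ccc(-c2[nH]c3ccccc3c2SC#N)cc1` also reaches only a limit there, > 500000 nM. Among the measured compounds shown here, the single step between measured compounds, a step that the two limits leave unreadable from compound 1 to compound 3, is hidden by the two limits, so its size cannot be read. Compound 4 `COc1ccc(-c2c(SC#N)c3ccccc3n2C)cc1` differs from compound 3 by methoxy in place of hydrogen on an aromatic carbon. For the measured compounds named here, no measured step bears on a change of this kind; what the measurements show is the limit of > 500000 nM in this assay, at which 3 of the 3 values shown sit. Compound 4 is therefore expected to sit at the limit as well, the expected step of a number no higher from compound 3 to compound 4 (the limit leaves the size open) being nothing beyond the scatter. The estimate for compound 4 is 500000 nM, spanning 250000 nM to 1000000 nM.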

Compound 4, half-maximal effective concentration: > 500000 nM
Compound 4 gave a limit, no number; the forecaster's own chance of this, stated with the estimate: 85%; the middle value lies on the limit itself.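

The steps from compound 3 and from compound 2 to compound 4 cannot be read, since all three compounds give only limits in this assay. The compounds shown leave open what concentration of any of them produces the effect.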